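Cyclohexylamino to isobutylamino: what to expect

The source may report more compounds than this note shows. Statements on the series, on what has been measured and on what is new or still open speak of the compounds shown alone.

Measured so far in an ADME assay on CCRF-HSB-2 cells (Homo sapiens) for cytotoxicity, with a stated time of 7 days; on this read-out higher numbers stand for lower toxicity in this test and lower numbers for higher toxicity in this test:
- Compound 1 `CC(C)CSc1nc(N)nc2c1ncn2/C=C1/CC1(CO)CO` | 60000 nM
- Compound 2 `Nc1nc(NC2CCCCC2)c2ncn(/C=C3/CC3(CO)CO)c2n1` | > 20000 nM (a limit, not a number)

Compound 2 has no number of its own, only the limit > 20000 nM in this assay.

Compound 3 `CC(C)CNc1nc(N)nc2c1ncn2/C=C1/CC1(CO)CO` differs from compound 2 by one change, (isobutyl in place of cyclohexyl on a nitrogen on an aromatic ring), so that cyclohexylamino becomes isobutylamino.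

Among the measured compounds shown here, the only measured step nearby is a step that the limit leaves unreadable from compound 1 to compound 2, and it gives no usable size. The closest guide is compound 1 at 60000 nM, which also carries isobutyl, there as isobutylsulfanyl. Together with the limit of > 20000 nM in this assay, at which 1 of the 2 values shown sits, this suggests that compound 3 should also need a high concentration to harm these cells.

The expected change is small, a step that the limit leaves unreadable from compound 2 to compound 3, and its direction cannot be fixed from these data.

For compound 3 the estimate is 35000 nM, with an expected range from 15000 nM to 90000 nM, and the result may again be only a limit.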

Compound 3, half-maximal cytotoxic concentration: > 20000 nM
Compound 3 ended at the assay's limit (the forecaster's own chance of this, stated with the estimate: 50%); the middle value does not contradict the limit.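

In this assay, among the compounds shown here, compound 3 gives only the limit > 20000 nM and so no step linking it to compound 1 or compound 2 can be read. The compounds shown leave open whether isobutyl in place of cyclohexyl changes toxicity to these cells at all: the limit of > 20000 nM in this assay, at which 2 of the 3 values shown sit.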